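The source may report more compounds than this note shows. Statements on the series, on what has been measured and on what is new or still open speak of the compounds shown alone.

Compound 1, `COc1ccc(CNC(=O)/C(C#N)=C/c2ccc(Br)o2)cc1`, in a functional assay on SMA cells (Homo sapiens) for inhibition, read by MTT assay, with a stated time of 72 h (a lower number here means a stronger inhibitor of growth, a higher number a weaker inhibitor of growth), gives 14000 nM. Compound 2, `COc1ccc(CNC(=O)/C(C#N)=C/c2cc(Br)co2)cc1`, in this assay reaches only a limit, > 100000 nM, which is a boundary of the measurement rather than a number. Among the measured compounds shown here, the one measured step, an at least 7.1-fold higher number from compound 1 to compound 2 (0.85 log units; beyond the scatter), therefore shows that compound 2 sits at the weak end of the pair, at the limit described by the limit of > 100000 nM in this assay, at which 1 of the 2 values shown sits. Compound 3, `COc1ccc(CNC(=O)/C(C#N)=C/c2ccc(C)cc2)cc1`, differs from compound 2 by 4-methylphenyl in place of 4-bromofuran-2-yl on a double-bonded chain carbon bound to a double-bonded chain carbon. For the measured compounds named here, no measured step exchanges the five-membered ring for a six-membered carbon ring, so the measured step gives no direct guide to the size or direction of this change in this assay; it tells only that compound 2 starts from a limit. Compound 3 is expected to give 30000 nM, with a range from 5000 nM to 100000 nM. The estimated step of an at least 3.3-fold lower number from compound 2 to compound 3 (0.52 log units; beyond the scatter) thus reflects an expectation of a measurable number rather than a limit.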

Compound 3, concentration for 50% growth inhibition: 42000 nM
Estimate against measurement, compound 3: 1.4-fold (0.15 log units) below; the range from low to high includes it.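

In this assay, the exchange at this place on a double-bonded chain carbon gives an at least 2.3-fold lower number from compound 2 to compound 3 (0.37 log units; beyond the scatter), so a six-membered aromatic ring of carbon only, carrying neither oxygen nor bromine, still gives a measurable growth inhibition. Set against the 5-bromofuran-2-yl group, however, 4-methylphenyl gives a 3.0-fold higher number from compound 1 to compound 3 (0.48 log units; beyond the scatter), which leaves compound 1 as the strongest of the three. Compound 2 remains a limit and not a number: the limit of > 100000 nM in this assay, at which 1 of the 3 values shown sits.

The ring and its substituent change together in these compounds, so it stays open which of the two accounts for the steps; 4-bromophenyl or 5-methylfuran-2-yl would separate them. As far as these compounds go, it also stays open how this place responds to a ring carrying an amine or a carboxylic acid.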